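Chloro in Place of Hydroxy: Expected Cytotoxicity Shift

The compounds below may be only part of what the source reports. "The series", "measured", "known", "first", "only" and "open" are said of these compounds alone.

Of the compounds shown here, two of a shared core have been tested in an ADME assay on J774 cells (Mus musculus, strain BALB/c) for cytotoxicity, read by resazurin assay, with a stated time of 72 h; on this read-out higher numbers stand for lower toxicity in this test and lower numbers for higher toxicity in this test. Compound 1 `CC(/C=N/N(C)c1ccc([N+](=O)[O-])cc1)=N\NC(=O)c1ccc(N)cc1` gives 51700 nM in this assay, and compound 2 `CC(/C=N/Nc1ccc([N+](=O)[O-])cc1)=N\NC(=O)c1ccccc1O` gives 29500 nM. Compound 2 thus stands at the lower of the two numbers, but its gap to compound 1 lies within the usual scatter, so the two cannot be told apart on this evidence.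

Compound 3 `CC(/C=N/Nc1ccc([N+](=O)[O-])cc1)=N\NC(=O)c1ccccc1Cl` has not yet been measured. It differs from compound 2 in one place: chloro in place of hydroxy on an aromatic carbon. Among the compounds with values here, no measured pair in this set shows such a change, so there is nothing here to say how it moves the read-out.

Within the data shown here, with no comparable step to lean on, the expectation for compound 3 is a number close to that of compound 2, an estimated step of a 1.0-fold higher number from compound 2 to compound 3 (0.01 log units; within the scatter) that stays within the scatter. Compound 3 is therefore estimated at 30000 nM, with a range from 12000 nM to 75000 nM.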

Compound 3, half-maximal cytotoxic concentration: > 100000 nM
Compound 3 gave a limit, no number (the forecaster's own chance of this, stated with the estimate: 15%); middle value at least 3.3-fold (0.52 log units) away from the limit.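

Compound 3 carries a limit, not a number, in this assay: > 100000 nM. Even so, placing chloro in place of hydroxy on this aromatic carbon, ortho to a large group, gives an at least 3.3-fold higher number from compound 2 to compound 3 (0.53 log units; beyond the scatter), so this single change moves the read-out towards lower toxicity in this test, a shift that the gap between the two earlier compounds could not show. The full size of the step cannot be read, because compound 3 sits at a limit: the limit of > 100000 nM in this assay, at which 1 of the 3 values shown sits.

From the compounds shown here alone, what remains open is whether the shift comes from losing the hydroxy or from gaining the chloro. Comparing a methoxy, a fluoro or an amine at this same place would help separate those two readings and show how far the change extends.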